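A few compounds are considered here, and "the series" means these few. Any claim that something is new, unique, unknown or untested is made for them only; others in the source may bear on it.

Measured compounds in a toxicity assay on Vero cells (Chlorocebus sabaeus) for cytotoxicity; on this read-out higher numbers stand for lower toxicity in this test and lower numbers for higher toxicity in this test:
- compound 1 `COc1nc(C(C)(C)C)ccc1[C@@H](c1ccccc1)[C@@](O)(CCN(C)C)c1cccc2ccccc12`: 27.6 ug/mL
- compound 2 `COc1nc(-c2cccc(Cl)c2)ccc1[C@@H](c1ccccc1)[C@@](O)(CCN(C)C)c1cccc2ccccc12`: a limit of the assay, > 50 ug/mL
- compound 3 `COc1ccc(-c2ccc([C@@H](c3ccccc3)[C@@](O)(CCN(C)C)c3cccc4ccccc34)c(OC)n2)cc1`: a limit of the assay, > 50 ug/mL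

Among the compounds with values here, compound 1 holds the only number among the three values; the other two are limits, since (the limit of > 50 ug/mL in this assay, at which 2 of the 3 values shown sit).

Compound 4 `COc1nc(-c2ccccc2Cl)ccc1[C@@H](c1ccccc1)[C@@](O)(CCN(C)C)c1cccc2ccccc12` differs from compound 1 by 2-chlorophenyl in place of tert-butyl on an aromatic carbon. Within the data shown here, two measured steps bear on this change: an at least 1.8-fold higher number from compound 1 to compound 2 (0.25 log units; that floor lies within the scatter) and an at least 1.8-fold higher number from compound 1 to compound 3 (0.25 log units; that floor lies within the scatter), both replacing tert-butyl with a substituted phenyl and both running to the limit. A 2-chlorophenyl in the same place is expected to behave alike, so compound 4 is expected to reach or pass the limit, with a 1.8-fold higher number from compound 1 to compound 4 (0.26 log units; within the scatter). The estimate for compound 4 is 50 ug/mL, with a range from 25 ug/mL to 100 ug/mL.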

Compound 4, half-maximal cytotoxic concentration: > 50 ug/mL
Compound 4 ended at the assay's limit (the forecaster's own chance of this, stated with the estimate: 65%); the middle value lies on the limit itself.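

In this assay, 2-chlorophenyl in place of tert-butyl gives an at least 1.8-fold higher number from compound 1 to compound 4 (0.25 log units; that floor lies within the scatter), so a third substituted phenyl at this place next to the ring nitrogen ends the same way. Moving the chlorine from the 3-chlorophenyl of compound 2 to the 2-chlorophenyl of compound 4 leaves both compounds at the limit. The steps among compound 2, compound 3 and compound 4 cannot be read, because all three sit at that limit: the limit of > 50 ug/mL in this assay, at which 3 of the 4 values shown sit.

Going by these compounds, whether any phenyl differs from tert-butyl beyond the scatter stays open. So does the outcome of an amine or a carboxylic acid on the phenyl ring at this place.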